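From methyl to bromo in a well-tolerated series

A few compounds are considered here, and "the series" means these few. Any claim that something is new, unique, unknown or untested is made for them only; others in the source may bear on it.

- compound 1 `Cc1cccc(C(=O)Nc2ncc(-c3ccccc3)n2C)c1`: > 50000 nM (a limit)
- compound 2 `COc1ccc(-c2cnc(NC(=O)c3cccc(C)c3)n2C)cc1`: > 100000 nM (a limit)
- compound 3 `Cn1c(-c2ccccc2)cnc1NC(=O)c1cccc(Br)c1`: not yet measured

In a toxicity assay on THP-1 cells (Homo sapiens) for inhibition (a lower number here means that less compound is tolerated, a higher number that more compound is tolerated), compound 1 gives > 50000 nM, which is a limit and not a number. Compound 3 differs from it by a single swap: bromo in place of methyl on an aromatic carbon. Within the data shown here, the one measured step, a step that the two limits leave unreadable from compound 1 to compound 2, is a different change, and its size cannot be read. Compound 2 also stands at a limit, > 100000 nM. With both measured compounds at limits, no change beyond the scatter is expected, and the expected step is a number no higher from compound 1 to compound 3 (the limit leaves the size open). Compound 3 is expected at 50000 nM, with an estimated range of 20000 nM to 100000 nM.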

Compound 3, half-maximal cytotoxic concentration: > 50000 nM
Compound 3: no number, only a limit; the forecaster's own chance of this, stated with the estimate: 70%; the middle value sits exactly at the limit.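

No step from methyl to bromo can be read between compound 1 and compound 3, whose results are both limits: the limit of > 50000 nM in this assay, at which 2 of the 3 values shown sit.

The compounds shown leave open how much of any of them the cells actually tolerate.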